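This account rests on a few compounds, and the source may have more. Where it says the series, first, only, none or still open, it means among the compounds named here.

Working notes on the series, read in a toxicity assay on HepG2 2.2.15 cells (Homo sapiens) for cytotoxicity, read by CellTiter-Glo; on this read-out higher numbers stand for lower toxicity in this test and lower numbers for higher toxicity in this test. Compound 1 `O=C1CC(Oc2ncccn2)CN1c1cnn2c1CN(C(=O)Nc1cc(F)c(F)c(F)c1)C(C1CC1)C2` gives > 200000 nM, which is a limit of the assay and not a number. Compound 2 `O=C1CC(C(F)(F)F)CN1c1cnn2c1CN(C(=O)Nc1cc(F)c(F)c(F)c1)C(C1CC1)C2` gives 115000 nM. Compound 3 `O=C1CC(c2ccc(F)cc2)CN1c1cnn2c1CN(C(=O)Nc1cc(F)c(F)c(F)c1)C(C1CC1)C2` gives 32100 nM, the lower of the two actual numbers, so it is the most toxic of the three in this assay.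

Compound 4 `O=C1CC(c2ccccn2)CN1c1cnn2c1CN(C(=O)Nc1cc(F)c(F)c(F)c1)C(C1CC1)C2` carries pyridin-2-yl in place of 4-fluorophenyl on a saturated ring carbon. The change sits two ring bonds from the ring nitrogen.

For the measured compounds named here, two measured steps bear most directly on it, as both remove or install the 4-fluorophenyl at this same carbon: an at least 6.2-fold lower number from compound 1 to compound 3 (0.79 log units; beyond the scatter), and a 3.6-fold lower number from compound 2 to compound 3 (0.55 log units; beyond the scatter). The remaining step, an at least 1.7-fold lower number from compound 1 to compound 2 (0.24 log units; that floor lies within the scatter), says less, since it involves neither group in the new change. Neither group leaving or entering in the new change has been compared directly, so the read-across is loose. Compound 3 at 32100 nM still marks the low end of the series, and the other two substituents both sit higher.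

A modest move toward a higher number is therefore expected, and the expected size is a 2.2-fold higher number from compound 3 to compound 4 (0.34 log units; beyond the scatter). For compound 4 the estimated value is 70000 nM, with an expected range of 30000 nM to 180000 nM.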

Compound 4, half-maximal cytotoxic concentration: 96200 nM
Beside the measured number, compound 4's estimate is 1.4-fold (0.14 log units) below it, within the range that was stated.
By their numbers in this assay, from the lowest: compound 3; then compounds 4 and 2 (each within the scatter of the next). At a limit, above all of these: compound 1.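

In this assay, pyridin-2-yl in place of 4-fluorophenyl on the saturated ring carbon gives a 3.0-fold higher number from compound 3 to compound 4 (0.48 log units; beyond the scatter), so an aromatic six-membered ring at this carbon does not in itself bring the number down to the level of compound 3. Set against trifluoromethyl, pyridin-2-yl gives a 1.2-fold lower number from compound 2 to compound 4 (0.08 log units; within the scatter), so these two groups cannot be told apart here, and among the substituents shown only the 4-fluorophenyl of compound 3 stands apart at the low end. The comparison with (pyrimidin-2-yl)oxy, an at least 2.0-fold lower number from compound 1 to compound 4 (0.31 log units; beyond the scatter), is a floor only, as compound 1 stands at a limit of the assay and not a number: the limit of > 200000 nM in this assay, at which 1 of the 4 values shown sits.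

The step from compound 3 to compound 4 exchanges a ring carbon for a ring nitrogen and removes the fluorine in one move, and the compounds shown do not separate the two, which a plain phenyl at this carbon would begin to do. Also open, from the compounds shown here alone, is how a basic amine or a carboxylic acid at this carbon would read in this assay.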